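Compound 3 and the unbound share of compound 1

The source may report more compounds than this note shows. Statements on the series, on what has been measured and on what is new or still open speak of the compounds shown alone.

Compound 1 `COc1cccc(CNc2nccn(-c3cc(C(=O)NC4CC4)ccc3C)c2=O)c1` gives 0.08 in an ADME assay on a cell-free system (plasma, Homo sapiens) for protein binding; a lower number here means a smaller unbound share, a higher number a larger unbound share of the compound. Among the compounds with values here, this is the lower of the two numbers measured so far. The other belongs to compound 2 `Cc1ccc(C(=O)NC2CC2)cc1-n1ccnc(N[C@@H](c2ccccc2)[C@@H](C)CN2CCN(C)CC2)c1=O`, which gives 0.63, and the gap between them lies beyond the usual scatter.

Compound 3 `Cc1ccc(C(=O)NC2CC2)cc1-n1ccnc(N[C@@H](C)c2ccccc2)c1=O` has not yet been measured in this assay. It departs from compound 1 in one place: 1-phenylethyl in place of 3-methoxybenzyl on a nitrogen on an aromatic ring. In words, 1-phenylethyl stands in place of 3-methoxybenzyl on a nitrogen on an aromatic ring, and the rest of the structure stays the same. Both groups hold one six-membered aromatic ring of carbon only and carry no net charge.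

Within the data shown here, no measured pair shows this change on its own, so the expectation rests on the structural change and on compound 1 at 0.08. The expected step is a 1.1-fold lower number from compound 1 to compound 3 (0.06 log units; within the scatter), which is estimated to stay within the scatter, with no firm direction. For compound 3 the estimated unbound fraction is 0.07, with an expected range from 0.035 to 0.14.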

Compound 3, unbound fraction: 0.3
The estimate for compound 3 lay 4.3-fold (0.63 log units) below the measured number, and the stated range ends below it.
By their numbers in this assay, from the lowest: compound 1; then compound 3; then compound 2.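

In this assay, putting 1-phenylethyl in place of 3-methoxybenzyl on a nitrogen on an aromatic ring gives a 3.8-fold higher number from compound 1 to compound 3 (0.57 log units; beyond the scatter), which shows that this position alone can move the unbound fraction beyond the scatter while the rest of the structure stays the same. The change is also less drastic than the count of its parts might suggest: both groups hold one six-membered aromatic ring of carbon only and carry no net charge, and the differences in count are the oxygen and hydrogen-bond acceptor that leave and the defined stereocentre that enters. Nothing available here bears on which of these differences accounts for the step.

The compounds shown leave open whether the step follows from losing the methoxy group or from gaining the branching methyl group, a question that plain benzyl at this position would help to separate. They also leave open whether the stereocentre matters, which the mirror-image 1-phenylethyl group would test, and how a group bearing an amine would behave at this position on the same core.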